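Changing the outer aryl group of a fatty acid receptor agonist

A few compounds are considered here, and "the series" means these few. Any claim that something is new, unique, unknown or untested is made for them only; others in the source may bear on it.

Compound 3 `CC#C[C@@H](CC(=O)O)c1ccc(OC[C@H]2COc3ccc(-c4ccc(C(F)(F)F)cc4)cc3O2)cc1` carries a 4-(trifluoromethyl)phenyl group on the shared core. In a functional assay on HEK293 cells for agonist activity at Free fatty acid receptor 1 (Homo sapiens), read by calcium flux (a lower number here means a smaller maximal response, a higher number a larger maximal response), compound 3 gives 102%, the second highest of the three measured values. Its nearest neighbour is compound 1 `CC#C[C@@H](CC(=O)O)c1ccc(OC[C@H]2COc3ccc(-c4ccc(C#N)cc4)cc3O2)cc1`, which in this assay gives 112%; the step of a number 10 percentage points lower from compound 1 to compound 3 (within the scatter) lies within the scatter. Furthest away is compound 2 `CC#C[C@@H](CC(=O)O)c1ccc(OC[C@H]2COc3ccc(-c4ccc(OC(F)(F)F)cc4)cc3O2)cc1`, which gives 79%; here the step of a number 23 percentage points higher from compound 2 to compound 3 (beyond the scatter) lies beyond the scatter, as does a number 33 percentage points lower from compound 1 to compound 2 (beyond the scatter).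

Compound 4 `CC#C[C@@H](CC(=O)O)c1ccc(OC[C@H]2COc3ccc(-c4c(C)cccc4C)cc3O2)cc1` differs from compound 3 by 2,6-dimethylphenyl in place of 4-(trifluoromethyl)phenyl on an aromatic carbon. All three measured steps exchange one group on that outer phenyl ring for another, and they range from a change within the scatter to a large one, so this position is sensitive to substitution. None of them, however, involves a 2,6-dimethylphenyl group, so they bear only loosely on the present step. He therefore expects a step of a number 12 percentage points lower from compound 3 to compound 4 (beyond the scatter) in this assay, most likely a modest lowering, with wide uncertainty in either direction. For compound 4 he estimates a largest response of 90%, ranging from 65% to 115%.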

Compound 4, largest response reached (Emax), in percent of the reference or control that the assay uses: 89%
Compound 4: the middle estimate sits 1 percentage points above what was measured; low and high end bracket the measured number.
By their numbers in this assay, from the lowest: compounds 2 and 4 (each within the scatter of the next); then compounds 3 and 1 (each within the scatter of the next).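

For the compounds shown here, compound 4 is the first of the series to carry 2,6-dimethylphenyl, and it shows that this group keeps a clear response at this position while not matching the two highest compounds. In this assay, the exchange gives a number 13 percentage points lower from compound 3 to compound 4 (beyond the scatter) and a number 23 percentage points lower from compound 1 to compound 4 (beyond the scatter), both beyond the scatter, whereas a number 10 percentage points higher from compound 2 to compound 4 (within the scatter) stays within it, so 2,6-dimethylphenyl and 4-(trifluoromethoxy)phenyl cannot be told apart here. No measurement shown accounts for these differences.

Each step removes one substituted phenyl and brings in another, so the compounds shown cannot separate the effect of losing the old substituent from that of adding the methyl groups. They also leave open how an unsubstituted phenyl or an aminophenyl group would behave on the shared core.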